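Urea substituent series on the shared core: phenyl for cyclohexyl

This account rests on a few compounds, and the source may have more. Where it says the series, first, only, none or still open, it means among the compounds named here.

Compound 1 `CC(=O)Nc1ccc2c(cnn2CC(=O)COc2ccc(Oc3ccccc3)cc2)c1`: 3900 nM
Compound 2 `CCNC(=O)Nc1ccc2c(cnn2CC(=O)COc2ccc(Oc3ccccc3)cc2)c1`: 1600 nM
Compound 3 `O=C(COc1ccc(Oc2ccccc2)cc1)Cn1ncc2cc(NC(=O)NC3CCCCC3)ccc21`: 840 nM

In an assay on microsomes from brain for inhibition of Fatty-acid amide hydrolase 1 (Rattus norvegicus), read by fluorescence and HPLC, with a stated time of 45 min (on this read-out higher numbers stand for weaker inhibition and lower numbers for stronger inhibition), compound 3 gives the lowest of the three numbers; the step of a 1.9-fold lower number from compound 2 to compound 3 (0.28 log units; within the scatter) lies within the scatter, while a 4.6-fold lower number from compound 1 to compound 3 (0.67 log units; beyond the scatter) and a 2.4-fold lower number from compound 1 to compound 2 (0.39 log units; beyond the scatter) are beyond it. Compound 4 `O=C(COc1ccc(Oc2ccccc2)cc1)Cn1ncc2cc(NC(=O)Nc3ccccc3)ccc21` differs from compound 3 by phenyl in place of cyclohexyl on an amide-type nitrogen. For the measured compounds named here, no measured step swaps one ring for another on this nitrogen; the only step that touches the group on it, a 1.9-fold lower number from compound 2 to compound 3 (0.28 log units; within the scatter), is within the scatter, so a step of no more than that size is expected. For compound 4 the expected value in this assay is 700 nM, range 250 nM to 2000 nM, a step of a 1.2-fold lower number from compound 3 to compound 4 (0.08 log units; within the scatter).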

Compound 4, half-maximal inhibitory concentration: 6000 nM
Beside the measured number, compound 4's estimate is 8.6-fold (0.93 log units) below it; the measured number lies above the stated range.
By their numbers in this assay, from the lowest: compounds 3 and 2 (each within the scatter of the next); then compounds 1 and 4 (each within the scatter of the next).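

In this assay, the ring type on this amide-type nitrogen matters: with the same count of heavy atoms, phenyl in place of cyclohexyl gives (a 7.1-fold higher number from compound 3 to compound 4 (0.85 log units; beyond the scatter)), and phenyl in place of ethyl gives (a 3.8-fold higher number from compound 2 to compound 4 (0.57 log units; beyond the scatter)). With the carbonyl carbon carrying anilino rather than methyl, the result is (a 1.5-fold higher number from compound 1 to compound 4 (0.19 log units; within the scatter)), so compound 4, unlike compound 2 and compound 3, keeps no step beyond the scatter from compound 1. Nothing at hand accounts for the gap between the two rings. Open, as far as these compounds go, is whether benzyl, cyclopentyl or a substituted phenyl on this nitrogen would sit nearer compound 3 or compound 4.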